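Cytotoxicity notes: compound 2 to compound 3

A few compounds are considered here, and "the series" means these few. Any claim that something is new, unique, unknown or untested is made for them only; others in the source may bear on it.

compound 1 `COc1cc2ncnc(-n3cnc(-c4ccccn4)n3)c2cc1OC` — > 27000 nM
compound 2 `COc1cc2ncnc(-n3nc(-c4ccccn4)nc3N)c2cc1OCc1ccccc1` — > 27000 nM

Two members of the series have been run in an ADME assay on BJ cells (Homo sapiens) for cytotoxicity, with a stated time of 72 h; on this read-out lower numbers stand for an effect already at smaller amounts and higher numbers for an effect only at larger amounts of compound. For compound 1 the entry > 27000 nM is a limit of the assay and not a number. For compound 2 the entry > 27000 nM is likewise a limit of the assay. Compound 2 therefore stands at the edge of what this assay reports, together with the only other entry: the limit of > 27000 nM in this assay, at which 2 of the 2 values shown sit. Of the gap between compound 1 and compound 2 nothing can be said beyond the fact that both sit at that limit.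

Compound 3 `COc1cc2ncnc(-n3nc(-c4ccccn4)nc3N)c2cc1OCCCNC(=O)C(F)(F)F` has not yet been measured in this assay. Relative to compound 2 it carries 2-(((trifluoromethyl)carbonyl)amino)ethyl in place of phenyl on a saturated chain carbon bound to an oxygen on an aromatic ring. Within the data shown here, no step between measured compounds is available to calibrate a change of this kind, and the two entries at hand are both limits, so no trend can be drawn on.

The step that the limit leaves unreadable from compound 2 to compound 3 is expected to be none beyond the scatter. Compound 3 is expected to give 40000 nM, within a range of 18000 nM to 120000 nM, with a limit rather than a number the most likely report.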

Compound 3, half-maximal effective concentration: > 7000 nM
Compound 3 ended at the assay's limit; the forecaster's own chance of this, stated with the estimate: 80%; the middle value lies beyond the limit too.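

In this assay compound 3 gives > 7000 nM, a limit of the assay and not a number. Compound 2 also carries only a limit, so no step can be read between compound 2 and compound 3. The compounds shown leave open whether benzyloxy and 3-(((trifluoromethyl)carbonyl)amino)propoxy differ at all in this assay.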